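The source may hold more compounds than are shown below. What is called first, only, known or untested is meant among the compounds shown, and "the series" means these compounds.

Working notes on a short set built on a shared core, all tested in an assay on cells for displacement of a labelled ligand from somatostatin receptor type 2 (Homo sapiens), with a stated time of 90 min; a lower number here means a stronger inhibitor, a higher number a weaker inhibitor. Compound 1 `Clc1ccc(Cn2c(CCc3c[nH]cn3)nnc2Cc2c[nH]c3ccccc23)cc1Cl` opens the set. In this assay compound 1 returns only the limit > 10000 nM, which is a limit of the assay and not a number. Compound 2 `c1ccc(Cn2c(Cc3c[nH]c4ccccc34)nnc2C2CCNCC2)cc1` follows. In this assay compound 2 likewise reaches only the limit > 10000 nM. Compound 3 `NCCCn1c(CCc2c[nH]c3ccccc23)nnc1Cc1ccc(Cl)c(Cl)c1` carries a 3-aminopropyl chain on an aromatic nitrogen of the core. In this assay compound 3 sits at the limit > 10000 nM, again a limit rather than a number. Compound 3 therefore stands level with the rest of the set, every value shown being the same limit (the limit of > 10000 nM in this assay, at which 3 of the 3 values shown sit).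

The step to compound 4 `Clc1ccc(Cc2nnc(CCc3c[nH]c4ccccc34)n2CCCc2c[nH]cn2)cc1Cl` is 1H-imidazol-4-yl in place of amino on a saturated chain carbon, three bonds along the chain from an aromatic nitrogen. For the measured compounds named here, no measured pair in the set differs in one place, so there is no measured step to lean on; the only anchor is that compound 3 and the two others all sit at the limit. The change is expected to move the number in this assay little, if at all, beyond the scatter. Compound 4 is therefore expected at 10000 nM, within 3000 nM to 30000 nM, and most likely reported once more as a limit. The expected step from compound 3 to compound 4 is a number no higher from compound 3 to compound 4 (the limit leaves the size open).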

Compound 4, inhibition constant: > 10000 nM
Compound 4: no number, only a limit (the forecaster's own chance of this, stated with the estimate: 80%); the middle value sits exactly at the limit.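

For the compounds shown here, compound 3 and compound 4 each return only a limit in this assay, not a number, so no step between them can be read. The compounds shown leave open whether any change on the shared core gives a measurable value, as all of them stand at one limit: the limit of > 10000 nM in this assay, at which 4 of the 4 values shown sit.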